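The source may hold more compounds than are shown below. What is called first, only, known or untested is meant among the compounds shown, and "the series" means these compounds.

- Compound 1 `O=C(/C=C/c1ccccc1Cl)c1ccc(OCc2ccccc2)cc1`: 7100 nM
- Compound 2 `Cc1ccc(COc2ccc(C(=O)/C=C/c3ccccc3)cc2)cc1`: 43200 nM

In a functional assay on CAL-51 cells (Homo sapiens) for inhibition, read by sulforhodamine B assay, with a stated time of 3 days (a higher number here means a weaker inhibitor of growth, a lower number a stronger inhibitor of growth), compound 2 stands highest of the two at 43200 nM, while compound 1 lies clearly lower at 7100 nM. Compound 3 `O=C(/C=C/c1ccccc1)c1ccc(OCc2ccccc2)cc1` differs from compound 2 by hydrogen in place of methyl on an aromatic carbon. For the measured compounds named here, no measured step isolates this change, so only a modest downward move in this assay is expected, and it may stay within the scatter. The expected step is a 1.7-fold lower number from compound 2 to compound 3 (0.24 log units; within the scatter). Compound 3 is estimated at 25000 nM, with an expected range of 9000 nM to 60000 nM.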

Compound 3, concentration for 50% growth inhibition: 28900 nM
Beside the measured number, compound 3's estimate is 1.2-fold (0.06 log units) below it; the measured number falls inside the stated range.
By their numbers in this assay, from the lowest: compound 1; then compounds 3 and 2 (each within the scatter of the next).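

In this assay, hydrogen in place of methyl at this place, para to a large group, gives a 1.5-fold lower number from compound 2 to compound 3 (0.17 log units; within the scatter), so the two compounds cannot be told apart at this position. For the compounds shown here, compound 3 also links to compound 1 through a single change, the loss of the chloro group, which gives a 4.1-fold higher number from compound 1 to compound 3 (0.61 log units; beyond the scatter), the only step here beyond the scatter. No measurement shown accounts for either step. The compounds shown leave open whether chloro in the place of the methyl would give a step of similar size, and how a methoxy group or an amine would read at either place.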